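From Imidazole to Benzimidazole: Expected Effect on Inhibition

The compounds below may be only part of what the source reports. "The series", "measured", "known", "first", "only" and "open" are said of these compounds alone.

Of the compounds shown here, two have been tested in an in vitro assay on V79MZ cells for inhibition of cytochrome P450 11B1, mitochondrial (Homo sapiens); a higher number here means a weaker inhibitor, a lower number a stronger inhibitor. Compound 1 `c1ccc(-c2cccc(Cn3cnc4ccccc43)c2)cc1` gives 369 nM in this assay, and compound 2 `c1ccc(C(CCn2ccnc2)(c2ccccc2)c2ccccc2)cc1` gives 80 nM. Of these two numbers, compound 2 has the lower one and so the stronger inhibition; the gap to compound 1 lies beyond the usual scatter. Compound 3 `c1ccc(C(CCn2cnc3ccccc32)(c2ccccc2)c2ccccc2)cc1` has not yet been measured. It differs from compound 2 in one place: 1H-benzimidazol-1-yl in place of 1H-imidazol-1-yl on a saturated chain carbon, three bonds along the chain from three aromatic carbons. Going by the values given here, no measured pair shows this exact change on the shared core of compound 2, so its effect cannot be read from the data. Compound 1 carries the entering group on a different core, and there it gives 369 nM, which hints that this group need not improve inhibition. The step from compound 2 to compound 3 is expected to be modest, if anything toward a weaker inhibitor, a 1.9-fold higher number from compound 2 to compound 3 (0.27 log units; within the scatter). Compound 3 is therefore estimated at 150 nM, with a range from 40 nM to 600 nM.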

Compound 3, half-maximal inhibitory concentration: > 1000 nM
Compound 3 was reported as a limit; the forecaster's own chance of this, stated with the estimate: 3%; middle value at least 6.6-fold (0.82 log units) away from the limit.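

On the shared core of compound 2, placing 1H-benzimidazol-1-yl instead of 1H-imidazol-1-yl on the saturated chain carbon gives an at least 12-fold higher number from compound 2 to compound 3 (1.09 log units; beyond the scatter) in this assay, the first measured view of this change on a single core. Both groups count the same hydrogen-bond acceptors and donors and carry no net charge, so a large loss of inhibition accompanies the added six-membered aromatic ring of carbon only, showing that inhibition is highly sensitive to this change at this position. The result for compound 3 is a limit of the assay, not an exact number: the limit of > 1000 nM in this assay, at which 1 of the 3 values shown sits.

As far as these compounds go, how far inhibition falls therefore remains open, as does which feature of the added ring matters. Nor do these compounds show whether a methyl group on the imidazole or a longer chain would preserve inhibition.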